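From 2-bromophenyl to 3-bromophenyl on the carbonyl carbon

The source may report more compounds than this note shows. Statements on the series, on what has been measured and on what is new or still open speak of the compounds shown alone.

In a functional assay on MCF7 cells (Homo sapiens) for inhibition, read by MTT assay, with a stated time of 24 h (a higher number here means a weaker inhibitor of growth, a lower number a stronger inhibitor of growth), compound 1 (`Cn1cc(-c2nc3ccccc3n2C(=O)c2cccc(Br)c2)c2ccccc21`) gives 63400 nM and compound 2 (`COc1ccc2c(c1)c(-c1nc3ccccc3n1C(=O)c1ccccc1)cn2C`) gives 38400 nM while compound 3 (`COc1ccc2c(c1)c(-c1nc3ccccc3n1C(=O)c1ccccc1Br)cn2C`) gives 55800 nM in the same read-out. Compound 3 therefore lies within the scatter of both compound 1 and compound 2, and its number cannot be separated from either.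

The next structure is compound 4 (`COc1ccc2c(c1)c(-c1nc3ccccc3n1C(=O)c1cccc(Br)c1)cn2C`). The change is 3-bromophenyl in place of 2-bromophenyl on a carbonyl carbon, so the two compounds have the same atoms, joined differently.

Going by the values given here, no measured step isolates this change. Among the compounds with values here, the closest evidence is the single step that introduces bromo in place of hydrogen on an aromatic carbon, a 1.5-fold higher number from compound 2 to compound 3 (0.16 log units; within the scatter) and this step stays within the scatter. Compound 1 also carries 3-bromophenyl on its carbonyl carbon and gives 63400 nM on a different core, which offers only indirect support.

No step beyond the scatter is therefore expected in this assay, and no direction is favoured. The estimated move is a 1.0-fold lower number from compound 3 to compound 4 (0.01 log units; within the scatter) and it amounts to no real change. For compound 4 the estimate is 55000 nM and the expected range runs from 30000 nM to 95000 nM in this read-out.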

Compound 4, concentration for 50% growth inhibition: 52700 nM
Beside the measured number, compound 4's estimate is 1.0-fold (0.02 log units) above it, within the range that was stated.
By their numbers in this assay, from the lowest: compounds 2, 4, 3 and 1 (each within the scatter of the next).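

In this assay the change from 2-bromophenyl to 3-bromophenyl on the carbonyl carbon now has a direct reading on the shared core, a 1.1-fold lower number from compound 3 to compound 4 (0.02 log units; within the scatter), so the two placements of the bromo cannot be told apart here. The 3-bromophenyl group also gives a reading against compound 2, which carries no bromo, of a 1.4-fold higher number from compound 2 to compound 4 (0.14 log units; within the scatter), so neither placement separates from hydrogen, while methoxy in place of hydrogen on the core reads a 1.2-fold lower number from compound 1 to compound 4 (0.08 log units; within the scatter) and adds no separable effect when 3-bromophenyl is present. No supporting measurement bears on this result.

The compounds shown leave open whether any group on this aromatic ring can move the number beyond the scatter, for example an amine or a carboxylic acid in place of the bromo. They also leave open whether the carbonyl carbon itself matters, which a longer chain carrying the same 3-bromophenyl group could test against compound 4.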